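A Hydroperoxide Swapped for an Alcohol

A few compounds are considered here, and "the series" means these few. Any claim that something is new, unique, unknown or untested is made for them only; others in the source may bear on it.

Measured so far in an ADME assay on C3H 10T1/2 cells (Mus musculus) for cytotoxicity, read by fluorescence, with a stated time of 24 h; on this read-out lower numbers stand for stronger inhibition and higher numbers for weaker inhibition:
Compound 1 `CC(C)=CCCC1(C)CCc2c(CCC(=O)c3ccc(O)cc3O)ccc(O)c2O1`: > 75000 nM
Compound 2 `C=C1C(=O)O[C@H]2/C=C(\C)C[C@@H]3C=C(C/C=C/[C@@](C)(OO)CC[C@H]12)C(=O)O3`: > 55600 nM
Compound 3 `C=C1C(=O)O[C@H]2/C=C(\C)C[C@@H]3C=C(CC[C@@H](OO)C(=C)CC[C@H]12)C(=O)O3`: > 27800 nM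

All three entries are limits of the assay, not numbers. Compound 2 therefore stands only at its limit of > 55600 nM. Compound 4 `C=C1C(=O)O[C@H]2/C=C(\C)C[C@@H]3C=C(C/C=C/[C@@](C)(O)CC[C@H]12)C(=O)O3` differs from it in one place: hydrogen in place of hydroxy on an oxygen on a saturated carbon. In words, this is hydrogen in place of hydroxy on an oxygen on a saturated carbon, or hydroxyoxy to hydroxy. Going by the values given here, no measured pair shows this change, so this assay offers no direct guide, and no shift beyond the scatter is expected. The estimated size is a step that the limit leaves unreadable from compound 2 to compound 4, with no direction firmly expected. For compound 4 the estimate is 58000 nM, with an expected range of 20000 nM to 100000 nM.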

Compound 4, half-maximal inhibitory concentration: > 50000 nM
Compound 4 ended at the assay's limit (the forecaster's own chance of this, stated with the estimate: 85%); the middle value lies beyond the limit too.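

In this assay, going by these compounds alone, compound 2 and compound 4 both end at limits, not numbers, so no step between them can be read. Going by these compounds, whether the change from hydroxyoxy to hydroxy shifts this read-out at all remains open.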